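This account rests on a few compounds, and the source may have more. Where it says the series, first, only, none or still open, it means among the compounds named here.

Working notes on the series, written at the step from compound 2 to compound 3.

In an ADME assay on liver for metabolic stability, with Liver microsome (Homo sapiens) as the target, read by LC-MS, using microsomes, tested at 1 uM (a lower number here means that the compound disappears faster, a higher number that the compound lasts longer), two numbers stand so far. Compound 1 `CCNC(=O)c1cc(N)c(Nc2ccc(C#N)cc2)cc1Oc1c(C)cc(CCC#N)cc1C` gives 2.88 h. Compound 2 `CC(=O)OCc1cc(N)c(Nc2ccc(C#N)cc2)cc1Oc1c(C)cc(CCC#N)cc1C` gives 0.17 h, the lowest of the two. Among the measured compounds shown here, the single measured step reads a 17-fold lower number from compound 1 to compound 2 (1.23 log units; beyond the scatter), an exchange of the whole group on an aromatic carbon.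

The next compound, compound 3 `Cc1cc(CCC#N)cc(C)c1Oc1cc(Nc2ccc(C#N)cc2)c(N)cc1COC(=O)C1CC1`, differs from compound 2 by cyclopropyl in place of methyl on a carbonyl carbon. For the measured compounds named here, no measured step touches this carbonyl carbon or any ester of the series; the one step known in this assay concerns a different place and a different pair of groups, so nothing among the measured compounds bears directly on the change from compound 2 to compound 3. Absent any such precedent, a step within the scatter is expected in this assay, without a direction, and the step from compound 2 to compound 3 is expected at a 1.5-fold higher number from compound 2 to compound 3 (0.17 log units; within the scatter). Compound 3 is estimated at 0.25 h, within 0.09 h to 0.7 h.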

Compound 3, half-life: 0.195 h
The estimate for compound 3 lay 1.3-fold (0.11 log units) above the measured number, and the stated range covers the measured number.
By their numbers in this assay, from the lowest: compounds 2 and 3 (each within the scatter of the next); then compound 1.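

In this assay, among the compounds shown here, the first change on this carbonyl carbon reads a 1.1-fold higher number from compound 2 to compound 3 (0.06 log units; within the scatter) and so leaves the number where it stood: with cyclopropyl or with methyl on the carbonyl carbon, the two esters cannot be told apart. The step of a 15-fold lower number from compound 1 to compound 3 (1.17 log units; beyond the scatter) lies beyond the scatter and matches in direction the earlier step of a 17-fold lower number from compound 1 to compound 2 (1.23 log units; beyond the scatter), so both esters shown stand well under the ethylcarbamoyl compound, with neither going against this. Nothing available explains either step.

Two small groups on the carbonyl carbon say little about larger ones, so a tert-butyl group or a phenyl ring there remains an open case. From the compounds shown here alone, whether the low numbers belong to the ester itself is also open, and a hydroxymethyl group or a carboxylic acid on the aromatic carbon would bear on that.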